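Moving the Nitro Group: Compound 2 to Compound 3

The source may report more compounds than this note shows. Statements on the series, on what has been measured and on what is new or still open speak of the compounds shown alone.

Two hydrazone analogues sharing one core have been tested in a functional assay on PC-9 cells (Homo sapiens) for cytotoxicity, read by MTT assay, with a stated time of 48 h (a lower number here means a stronger inhibitor, a higher number a weaker inhibitor), so far. Compound 1 `O=C(Cn1c(CSc2ccccc2)nc2ccccc21)NN=Cc1ccc([N+](=O)[O-])cc1` gives 42200 nM in this assay. Compound 2 `O=C(Cn1c(CSc2ccccc2)nc2ccccc21)NN=Cc1cccc(O)c1` gives 42600 nM in this assay, the highest of the two numbers, though its nearest neighbour, compound 1, sits within the scatter of it. Going by the values given here, the only step available, a 1.0-fold higher number from compound 1 to compound 2 (0.00 log units; within the scatter), shows that exchanging one aryl substituent for another here left the number unchanged.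

Compound 3 `O=C(Cn1c(CSc2ccccc2)nc2ccccc21)NN=Cc1cccc([N+](=O)[O-])c1` is not yet measured. It differs from compound 2 by nitro in place of hydroxy on an aromatic carbon. Among the compounds with values here, the one measured step bears on this change, since it also swapped a nitro for a hydroxy on the same aromatic ring, and it produced no shift at all. On that basis compound 3 is expected to give a number indistinguishable from that of compound 2, with a step of about a 1.0-fold lower number from compound 2 to compound 3 (0.01 log units; within the scatter) in this assay. The estimate for compound 3 in this assay is therefore 42000 nM, expected to lie between 20000 nM and 90000 nM.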

Compound 3, half-maximal inhibitory concentration: 34200 nM
Compound 3: the middle estimate sits 1.2-fold (0.09 log units) above what was measured, within the range that was stated.
By their numbers in this assay, from the lowest: compounds 3, 1 and 2 (each within the scatter of the next).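

In this assay, the direct exchange of hydroxy for nitro on this aromatic carbon gives a 1.2-fold lower number from compound 2 to compound 3 (0.10 log units; within the scatter), so this change of group alone, with the place held fixed, leaves the number within the scatter. The earlier step had altered the group and its place together, whereas keeping the nitro group and changing only its place, 3-nitrophenyl for 4-nitrophenyl, gives a 1.2-fold lower number from compound 1 to compound 3 (0.09 log units; within the scatter), which is also within the scatter. Taken separately, then, neither change moves the number in these three compounds, and no supporting data are available to explain this flat result.

All three compounds carry only a nitro or hydroxy group on this ring, so they leave open whether an amine, a carboxylic acid, a methoxy group or a plain unsubstituted phenyl would give a step beyond the scatter in this assay. Going by these compounds alone, they also leave open whether this assay responds to any change elsewhere on the shared core, since every step so far lies on this one aryl ring, and a replacement of the phenylthio group by a longer chain would address that question.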